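Swapping the Side Group of Compound 3 for Hydroxyethyl

A few compounds are considered here, and "the series" means these few. Any claim that something is new, unique, unknown or untested is made for them only; others in the source may bear on it.

Compound 1 `O=C(O)[C@@H]1CCCN1C(=O)CN(c1nc(Cl)nc2[nH]cnc12)C1CC1` gives 7.29% in a functional assay on the whole organism (Tail, strain ICR) with Mus musculus as the target, in the tail flick test, with a stated time of 150 min, at a dose of 25 umol/kg by the oral route; a lower number here means a weaker effect, a higher number a stronger effect of the compound at the dose given.
Compound 2 `N=C(N)NCCC[C@H](NC(=O)CN(c1nc(Cl)nc2[nH]cnc12)C1CC1)C(=O)O` gives 7.19% in this assay.
Compound 3 `NC(=O)C[C@H](NC(=O)CN(c1nc(Cl)nc2[nH]cnc12)C1CC1)C(=O)O` gives 7.51% in this assay.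

On these numbers compound 3 stands highest of the three, yet compound 1 and compound 2 both lie within the scatter of it, so the three cannot be told apart. Compound 4 `C[C@@H](O)[C@H](NC(=O)CN(c1nc(Cl)nc2[nH]cnc12)C1CC1)C(=O)O` has not been measured; its change is 1-hydroxyethyl in place of carbamoylmethyl on a saturated chain carbon bound to an amide-type nitrogen and a carbonyl carbon. Within the data shown here, the only measured step that exchanges a side group on the shared core, a number 0.3 percentage points higher from compound 2 to compound 3 (within the scatter), stayed within the scatter. The step of a number 0.1 percentage points lower from compound 3 to compound 4 (within the scatter) is therefore expected to stay within the scatter too, with no clear direction. Compound 4 is estimated at 7.4%, with a range from 2% to 14%.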

Compound 4, a percentage reported as activity, at one dose (the size of the read-out at that dose, not a potency): 24%
Compound 4: the middle estimate sits 16.6 percentage points below what was measured, outside the stated range (above it).
By their numbers in this assay, from the lowest: compounds 2, 1 and 3 (each within the scatter of the next); then compound 4.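

The side group on the saturated chain carbon bound to an amide-type nitrogen and a carbonyl carbon can clearly change the result in this assay after all: 1-hydroxyethyl in place of carbamoylmethyl gives a number 16.5 percentage points higher from compound 3 to compound 4 (beyond the scatter) while the earlier exchange there stayed within the scatter. Compound 4 also stands clear of the other two, with a number 16.8 percentage points higher from compound 2 to compound 4 (beyond the scatter) and a number 16.7 percentage points higher from compound 1 to compound 4 (beyond the scatter) as well. Nothing available gives a reason for this rise.

Open, going by these compounds, is whether the rise goes with the hydroxy group or with the carbon part of 1-hydroxyethyl. A hydroxymethyl or an ethyl group in the same place would separate the two.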